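Aromatic group restored at the core in compound 4

The source may report more compounds than this note shows. Statements on the series, on what has been measured and on what is new or still open speak of the compounds shown alone.

Compound 3 `COc1cccc(CNCCCNc2ccnc3cc(CC4CCCCC4)ccc23)c1O` sits at the low end of the three measured compounds. In an ADME assay for permeability, using PAMPA, with a stated time of 30 min, at pH 7.4 (a lower number here means that the compound crosses the layer more slowly, a higher number that the compound crosses the layer faster), compound 3 gives 23 10^-6 cm/s. Compound 2 `COc1cccc(CNCCCNc2ccnc3cc(CCC(C)C)ccc23)c1O` is level with it: in this assay compound 2 gives 23 10^-6 cm/s, and no change at the digits printed from compound 2 to compound 3 (within the scatter). Compound 1 `COc1cccc(CNCCCNc2ccnc3cc(Oc4ccc(Cl)cc4)ccc23)c1O` stands apart from both: in this assay compound 1 gives 317 10^-6 cm/s, and a 14-fold lower number from compound 1 to compound 3 (1.14 log units; beyond the scatter).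

Compound 4 `COc1ccc(-c2ccc3c(NCCCNCc4cccc(OC)c4O)ccnc3c2)cc1` is the next step: 4-methoxyphenyl in place of cyclohexylmethyl on an aromatic carbon. Among the measured compounds shown here, two measured steps bear on it. The step of no change at the digits printed from compound 2 to compound 3 (within the scatter) shows that exchanging one saturated group for another at this position left the number unchanged. For the measured compounds named here, the step of a 14-fold lower number from compound 1 to compound 3 (1.14 log units; beyond the scatter) shows the only measured exchange between an aromatic group and a saturated group at this position, and it was large, with the aromatic group on the higher side. Compound 4 brings an aromatic ring back to this position, so an upward step a 6.5-fold higher number from compound 3 to compound 4 (0.81 log units; beyond the scatter) is expected, and it is expected to be large. Going by the values given here, the entering 4-methoxyphenyl is not the 4-chlorophenoxy of compound 1, and no measured pair tests that difference, so the range is kept wide. In this assay compound 4 is estimated at 150 10^-6 cm/s, with a range of 50 10^-6 cm/s to 400 10^-6 cm/s.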

Compound 4, apparent permeability: 237 10^-6 cm/s
Compound 4: the middle estimate sits 1.6-fold (0.20 log units) below what was measured, within the range that was stated.
By their numbers in this assay, from the lowest: compounds 2 and 3 (each within the scatter of the next); then compounds 4 and 1 (each within the scatter of the next).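

In this assay there is a 10-fold higher number from compound 3 to compound 4 (1.01 log units; beyond the scatter) and a 10-fold higher number from compound 2 to compound 4 (1.01 log units; beyond the scatter) at this position, so the gap between aromatic and saturated groups no longer rests on compound 1 alone. Against compound 1 the result is a 1.3-fold lower number from compound 1 to compound 4 (0.13 log units; within the scatter) and so 4-methoxyphenyl and 4-chlorophenoxy, two different aromatic groups, stay level here, much as the two saturated groups did with no change at the digits printed from compound 2 to compound 3 (within the scatter) in the earlier pair. Across the four compounds the two carrying an aromatic ring at this position form the high pair and the two carrying a saturated group form the low pair, and no compound shown goes against this grouping.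

Still open is whether an aromatic ring is the only kind of group that gives the high numbers, since the compounds shown say nothing about an amine, a carboxylic acid, a longer chain or a ring containing nitrogen at this position. No measurement among those shown accounts for the gap between the aromatic and saturated pairs.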